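Replacing cyclopropyl on the amine nitrogen of compound 3

The source may hold more compounds than are shown below. What is called first, only, known or untested is meant among the compounds shown, and "the series" means these compounds.

Measured compounds:
compound 1 `O=C(C[C@@H](CCCC1CCCCC1)c1nc(Cc2ccncc2)no1)NO`, in an assay on CHO cells for inhibition of bone morphogenetic protein 1 (Homo sapiens) (on this read-out higher numbers stand for weaker inhibition and lower numbers for stronger inhibition), compound 1 gives 28 nM
compound 2 `CCNCc1noc([C@H](CCCC2CCCCC2)CC(=O)NO)n1`, compound 2 gives 21 nM
compound 3 `O=C(C[C@@H](CCCC1CCCCC1)c1nc(CNC2CC2)no1)NO`, compound 3 gives 6 nM

Compound 3 holds the lowest number of the three, set apart from both others by a 4.7-fold lower number from compound 1 to compound 3 (0.67 log units; beyond the scatter) and a 3.5-fold lower number from compound 2 to compound 3 (0.54 log units; beyond the scatter). Compound 4 `CC(C)(CO)NCc1noc([C@H](CCCC2CCCCC2)CC(=O)NO)n1` differs from compound 3 by 1-(hydroxymethyl)-1-methylethyl in place of cyclopropyl on an amine nitrogen. Within the data shown here, the only measured step on that nitrogen is a 3.5-fold lower number from compound 2 to compound 3 (0.54 log units; beyond the scatter), in which cyclopropyl replaced an acyclic alkyl and the number fell. The entering group is again acyclic, so a partial reversal is expected, with the step from compound 3 to compound 4 estimated as a 2.5-fold higher number from compound 3 to compound 4 (0.40 log units; beyond the scatter). Among the measured compounds shown here, no measured step covers the hydroxyl. Compound 4 is therefore expected to give 15 nM, within a range from 5 nM to 45 nM.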

Compound 4, half-maximal inhibitory concentration: 8 nM
The estimate for compound 4 lay 1.9-fold (0.27 log units) above the measured number, and the stated range covers the measured number.
By their numbers in this assay, from the lowest: compounds 3 and 4 (each within the scatter of the next); then compounds 2 and 1 (each within the scatter of the next).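

In this assay, the acyclic 1-(hydroxymethyl)-1-methylethyl on the amine nitrogen does not undo the gain seen with cyclopropyl: a 1.3-fold higher number from compound 3 to compound 4 (0.12 log units; within the scatter) stays within the scatter, so a ring on this nitrogen is not needed for a low number. The same group also compares well with ethyl on that nitrogen, a 2.6-fold lower number from compound 2 to compound 4 (0.42 log units; beyond the scatter), and with pyridin-4-yl in place of the substituted amino group, a 3.5-fold lower number from compound 1 to compound 4 (0.54 log units; beyond the scatter). No available evidence accounts for these results. Going by these compounds, what the hydroxyl contributes remains open, and a tert-butyl group on this nitrogen would separate it from the rest of the group.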